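A few compounds are considered here, and "the series" means these few. Any claim that something is new, unique, unknown or untested is made for them only; others in the source may bear on it.

Measured so far:
compound 1, `CC(=O)N[C@@H]1CCC[C@H](C(=O)Nc2cc(-c3cnn4c3CC(C)(C)C4)c(Cl)cn2)C1` — 73 uL/min in an ADME assay on cells (Hepatocyte, Rattus norvegicus) for metabolic stability, using equilibrium dialysis; a lower number here means slower removal, a higher number faster removal of the compound
compound 2, `CC(=O)N[C@@H]1CCC[C@H](C(=O)Nc2cc(-c3cnn4c3CC(C)(C)C4)c(C#N)cn2)C1` — 47 uL/min in this assay

Going by the values given here, compound 2 carries the smaller of the two numbers, but the only measured step, a 1.6-fold lower number from compound 1 to compound 2 (0.19 log units; within the scatter), is within the scatter, so the two compounds cannot be told apart on these data. Compound 3, `CC(=O)N[C@@H]1CCC[C@H](C(=O)Nc2cc(-c3cnn4c3CC(C)(C)C4)c(C)cn2)C1`, is the next compound, differing from compound 2 by methyl in place of cyano on an aromatic carbon.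

Among the compounds with values here, the single measured step is the only one that bears on this change, and it exchanged one substituent for another at the same aromatic carbon without moving the number beyond the scatter. Within the data shown here, no measured compound carries a methyl at that position, so nothing shows a direction for the methyl itself. The step from compound 2 to compound 3 is therefore expected to be a 1.3-fold higher number from compound 2 to compound 3 (0.11 log units; within the scatter), with no change beyond the scatter. Compound 3 is estimated at 60 uL/min, in the range 30 uL/min to 120 uL/min.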

Compound 3, intrinsic clearance in a liver preparation (reported as CLH), per the amount of preparation that the assay uses in the Hepatocyte assay: 53 uL/min
Compound 3: middle estimate off by 1.1-fold (0.05 log units), on the high side, and the stated range covers the measured number.
By their numbers in the Hepatocyte assay, from the lowest: compounds 2, 3 and 1 (each within the scatter of the next).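

In the Hepatocyte assay the methyl group at this aromatic carbon gives no readable change from either earlier substituent (a 1.1-fold higher number from compound 2 to compound 3 (0.05 log units; within the scatter); a 1.4-fold lower number from compound 1 to compound 3 (0.14 log units; within the scatter)), so chloro, cyano and methyl all lie within the scatter of one another here. In a physicochemical assay for solubility, in phosphate buffer, at pH 7.4 (a higher number here means a more soluble compound, a lower number a less soluble compound), compound 2 gives 380000 nM and compound 3 gives 600000 nM, and this change also stays within the scatter there (a 1.6-fold higher number from compound 2 to compound 3 (0.20 log units; within the scatter)). Nothing available offers an explanation for these results.

The compounds shown leave open whether a different kind of group at this aromatic carbon, such as an amine or a carboxylic acid, would move the number in the Hepatocyte assay beyond the scatter. On these data alone, whether a longer chain there would do so in the physicochemical assay also remains open.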